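The source may hold more compounds than are shown below. What is called first, only, known or untested is meant among the compounds shown, and "the series" means these compounds.

Measured compounds:
Compound 1 `CCN(CC)c1ccc(-c2cccc(OC)c2)nn1` gives > 25000 nM
Compound 2 `CC(=O)c1ccc(-c2ccc(N3CCCC3)nn2)cc1` gives > 25000 nM
Compound 3 `COc1ccc(Nc2ccc(-c3ccccc3)nn2)cc1` gives > 25000 nM

In an ADME assay on cells (Fibroblast, Homo sapiens) for antiproliferative activity, with a stated time of 48 h (on this read-out lower numbers stand for stronger inhibition and higher numbers for weaker inhibition), compound 1 reads > 25000 nM and this is a limit of the assay, not a number. Compound 2 and compound 3 also read as limits, so compound 1 stands at the limit of > 25000 nM in this assay, at which 3 of the 3 values shown sit, and no measured number separates it from the other two.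

Compound 4 `CCN(CC)c1ccc(-c2cccc(Cl)c2)nn1` differs from compound 1 in one place: chloro in place of methoxy on an aromatic carbon and this change sits on a six-membered aromatic ring of carbon only, meta to a large group.

Among the measured compounds shown here, no pair of measured compounds differs in a single place, so no measured step can size this change. The expectation rests on compound 1, whose reading of > 25000 nM is a limit, and no step beyond the usual scatter is expected in this assay in either direction.

For compound 4 the estimated value is 25000 nM with an expected range from 10000 nM to 50000 nM on repeated measurement. This expected outcome corresponds to a number no higher from compound 1 to compound 4 (the limit leaves the size open) as estimated here.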

Compound 4, half-maximal inhibitory concentration: > 25000 nM
Compound 4 ended at the assay's limit (the forecaster's own chance of this, stated with the estimate: 75%); the middle value lies on the limit itself.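

In this assay compound 4 gives > 25000 nM, which is a limit of the assay and not a number. Compound 1 also reads as a limit, so no step can be read for chloro in place of methoxy between compound 1 and compound 4: the limit of > 25000 nM in this assay, at which 4 of the 4 values shown sit.

The compounds shown leave open which change to the core, if any, would give a measured number in this assay.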